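A few compounds are considered here, and "the series" means these few. Any claim that something is new, unique, unknown or untested is made for them only; others in the source may bear on it.

Measured in an in vitro ADME assay on microsomes (Rattus norvegicus) for metabolic stability; a higher number here means faster removal of the compound, a lower number slower removal:
- compound 1 `O=C(CN1CC[C@@H](NC(=O)c2ccc(Cl)s2)C1)Nc1ccc(-n2ccccc2=O)cc1F`: 79.2 mL.min-1.g-1
- compound 2 `O=C(CN1C[C@H](NC(=O)c2ccc(Cl)s2)C[C@H]1CO)Nc1ccc(-n2ccccc2=O)cc1F`: 17.6 mL.min-1.g-1
- compound 3 `COC[C@@H]1C[C@@H](NC(=O)c2ccc(Cl)s2)CN1CC(=O)Nc1ccc(-n2ccccc2=O)cc1F`: 103 mL.min-1.g-1

Compound 3, at 103 mL.min-1.g-1, cannot be told apart from the unsubstituted ring of compound 1: the data show a 1.3-fold higher number from compound 1 to compound 3 (0.11 log units; within the scatter). The gap to the hydroxymethyl analogue is clear, with a 5.9-fold higher number from compound 2 to compound 3 (0.77 log units; beyond the scatter).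

The next structure is compound 4 `O=C(CN1C[C@H](NC(=O)c2ccc(Cl)s2)C[C@H]1CN1CCCC1)Nc1ccc(-n2ccccc2=O)cc1F`. It keeps the shared core and alters only the end of the side chain: pyrrolidin-1-yl in place of methoxy on a saturated chain carbon bound to a saturated ring carbon. In words, pyrrolidin-1-yl stands in place of methoxy on a saturated chain carbon bound to a saturated ring carbon.

Going by the values given here, three measured steps concern this same side chain. Adding hydroxymethyl gave a 4.5-fold lower number from compound 1 to compound 2 (0.65 log units; beyond the scatter), adding methoxymethyl gave a 1.3-fold higher number from compound 1 to compound 3 (0.11 log units; within the scatter), and capping the hydroxyl with methyl gave a 5.9-fold higher number from compound 2 to compound 3 (0.77 log units; beyond the scatter). So the lower number appears only with the free hydroxyl, and compound 4 has none, just as compound 3 has none at 103 mL.min-1.g-1. Among the compounds with values here, no measured compound carries a ring or a nitrogen at this spot, so the direction remains uncertain.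

The expected outcome is a 1.0-fold lower number from compound 3 to compound 4 (0.01 log units; within the scatter), with no clear move either way. For compound 4 the estimated value is 100 mL.min-1.g-1, with an expected range from 40 mL.min-1.g-1 to 250 mL.min-1.g-1.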

Compound 4, intrinsic clearance in microsomes: 116 mL.min-1.g-1
Beside the measured number, compound 4's estimate is 1.2-fold (0.06 log units) below it, and the stated range covers the measured number.
By their numbers in this assay, from the lowest: compound 2; then compounds 1, 3 and 4 (each within the scatter of the next).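

In this assay the side chain end can change from methoxy to pyrrolidin-1-yl, which brings in a ring and a nitrogen, with no readable shift: the data show a 1.1-fold higher number from compound 3 to compound 4 (0.05 log units; within the scatter). Compound 4 also sits level with the unsubstituted ring, with a 1.5-fold higher number from compound 1 to compound 4 (0.17 log units; within the scatter), yet it stands well clear of the hydroxymethyl analogue, with a 6.6-fold higher number from compound 2 to compound 4 (0.82 log units; beyond the scatter), so among the four compounds only compound 2 departs from the group formed by compounds 1, 3 and 4. No supporting measurement is available to explain why compound 2 alone gives the lower number.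

Going by these compounds, what remains open is whether that lower number belongs to the free hydroxyl specifically or could also appear with other groups at this place, such as a primary amine or a carboxylic acid on the same saturated chain carbon. A longer chain ending in hydroxy would show whether the hydroxyl must sit this close to the ring carbon, and a morpholine ring in place of pyrrolidin-1-yl would test how far the flat result for compound 4 extends.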